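The source may report more compounds than this note shows. Statements on the series, on what has been measured and on what is new or still open speak of the compounds shown alone.

Of the compounds shown here, two carry numbers so far. Compound 1 `C=CCNc1[nH]nc2nnn(-c3ccc(OCC)cc3)c(=O)c12` gives the lower of the two in a functional assay on CCRF-CEM cells (Homo sapiens) for cytotoxicity, read by resazurin assay, with a stated time of 48 h (on this read-out lower numbers stand for stronger inhibition and higher numbers for weaker inhibition), at 4730 nM; compound 2 `CCOc1ccc(NC(=O)CC#N)cc1`, a different scaffold, gives 14100 nM in this assay, a gap beyond the scatter. Compound 3 `CCNc1[nH]nc2nnn(-c3ccc(OCC)cc3)c(=O)c12` keeps the core of compound 1 and differs only by methyl in place of vinyl on a saturated chain carbon bound to a nitrogen on an aromatic ring, allyl to ethyl at the amino nitrogen. With no measured pair of this kind in the set, the step from compound 1 to compound 3 in this assay is expected to stay within the scatter, a 1.2-fold higher number from compound 1 to compound 3 (0.07 log units; within the scatter). Compound 3 is estimated at 5500 nM, within 2500 nM to 12000 nM.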

Compound 3, half-maximal inhibitory concentration: 15200 nM
Compound 3: the middle estimate sits 2.8-fold (0.44 log units) below what was measured; measured number outside the range, above it.
By their numbers in this assay, from the lowest: compound 1; then compounds 2 and 3 (each within the scatter of the next).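

The allylamino to ethylamino change on the shared core gives a 3.2-fold higher number from compound 1 to compound 3 (0.51 log units; beyond the scatter) in this assay, so this position responds to a small change in the chain, with vinyl leaving and methyl entering on a saturated chain carbon bound to a nitrogen on an aromatic ring. For the compounds shown here, this is the first single-place step, modest in size and resting on one pair. No available evidence bears on this step.

As far as these compounds go, whether a longer chain such as propyl or butyl, or a cyclopropylmethyl group, at this nitrogen would track compound 1 or compound 3 stays open. From the compounds shown here alone, a free amine in this place is equally open.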